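Adding One Carbon to 4-Methylphenyl

The source may report more compounds than this note shows. Statements on the series, on what has been measured and on what is new or still open speak of the compounds shown alone.

Of the compounds shown here, three with a shared core have been measured in an ADME assay on L02 cells (Homo sapiens) for inhibition, read by CCK-8 assay, with a stated time of 48 h (on this read-out higher numbers stand for weaker inhibition of growth and lower numbers for stronger inhibition of growth), so far. Compound 1 (`Cc1ccccc1Nc1nc(Nc2ccc(N3CCN(C)CC3)cn2)ncc1Cl`) reads 5980 nM and gives the lowest number. Compound 2 (`CN1CCN(c2ccc(Nc3ncc(Cl)c(NCc4ccc(F)cc4)n3)nc2)CC1`) reads 39700 nM and gives the highest. Compound 3 (`Cc1ccc(Nc2nc(Nc3ccc(N4CCN(C)CC4)cn3)ncc2Cl)cc1`) reads 13900 nM and stands second highest of the three.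

Compound 4 (`CCc1ccc(Nc2nc(Nc3ccc(N4CCN(C)CC4)cn3)ncc2Cl)cc1`) differs from compound 3 by methyl in place of hydrogen on a saturated chain carbon bound to an aromatic carbon, which makes 4-methylphenyl into 4-ethylphenyl. Among the compounds with values here, no measured step tests this change directly. The closest evidence is a 2.3-fold higher number from compound 1 to compound 3 (0.37 log units; beyond the scatter) for a swap from 2-methylphenyl to 4-methylphenyl, and a 2.9-fold lower number from compound 2 to compound 3 (0.46 log units; beyond the scatter) for a swap from 4-fluorobenzyl to 4-methylphenyl, while a 6.6-fold higher number from compound 1 to compound 2 (0.82 log units; beyond the scatter) completes the set. All three steps are modest, and each replaces a whole group. The smaller change here gives no basis for expecting a direction, so no step beyond the scatter is expected.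

For compound 4 the estimate is 12000 nM (expected range 6000 nM to 25000 nM). The expected result is a 1.2-fold lower number from compound 3 to compound 4 (0.06 log units; within the scatter) in this assay and nothing larger.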

Compound 4, concentration for 50% growth inhibition: 12100 nM
Compound 4: the middle estimate sits 1.0-fold (0.00 log units) below what was measured; measured number inside the range.
By their numbers in this assay, from the lowest: compound 1; then compounds 4 and 3 (each within the scatter of the next); then compound 2.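

In this assay, within the data shown here, extending 4-methylphenyl to 4-ethylphenyl gives a 1.1-fold lower number from compound 3 to compound 4 (0.06 log units; within the scatter), so this change at the saturated chain carbon bound to an aromatic carbon, which no earlier pair tested directly, stays within the scatter. The longer chain also leaves the steps from the other two compounds beyond the scatter, with a 3.3-fold lower number from compound 2 to compound 4 (0.52 log units; beyond the scatter) and a 2.0-fold higher number from compound 1 to compound 4 (0.31 log units; beyond the scatter), and both of these replace a whole group. Nothing given here accounts for how little the added methyl shifts the number.

Going by these compounds, what a propyl chain, or a chain ending in an amine or a carboxylic acid, would do at this place stays open. On these data alone, it is also open whether the same added methyl would stay within the scatter on the 2-methylphenyl group of compound 1.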